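Amide substituent change on an adenosine deaminase inhibitor series

The source may report more compounds than this note shows. Statements on the series, on what has been measured and on what is new or still open speak of the compounds shown alone.

Among the compounds with values here, compound 2 `C[C@H](O)[C@@H](CCc1cccc(C(=O)N(C)C)c1)n1cnc2c(N)ncnc21` is one of two compounds measured in an assay on isolated protein for inhibition of adenosine deaminase (Bos taurus), with a stated time of 5 min (a lower number here means a stronger inhibitor, a higher number a weaker inhibitor), where compound 2 gives 1.8 nM. Its only comparator, compound 1 `C[C@H](O)[C@@H](CCc1cccc(-c2cnccn2)c1)n1cnc2c(N)ncnc21`, gives 1.9 nM in this assay; the step of a 1.1-fold lower number from compound 1 to compound 2 (0.02 log units; within the scatter) lies within the scatter, so the two stand level. Compound 3 `C[C@H](O)[C@@H](CCc1cccc(C(=O)NC2CCCC2)c1)n1cnc2c(N)ncnc21` differs from compound 2 by cyclopentylamino in place of dimethylamino on a carbonyl carbon. Within the data shown here, no measured step changes the amide nitrogen substituents, so the single step from compound 1 to compound 2, which exchanged the whole aromatic substituent without moving the number beyond the scatter, is the only guide and bears on it indirectly, suggesting that this region of the structure accepts varied groups. On that basis compound 3 is expected to stay close to compound 2, with a step of a 1.4-fold higher number from compound 2 to compound 3 (0.14 log units; within the scatter) in this assay. The estimate for compound 3 is 2.5 nM, within a range from 0.8 nM to 8 nM.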

Compound 3, inhibition constant: 1.8 nM
Estimate against measurement, compound 3: 1.4-fold (0.14 log units) above; measured number inside the range.
By their numbers in this assay, from the lowest: compounds 2, 3 and 1 (each within the scatter of the next).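

In this assay, within the data shown here, cyclopentylamino in place of dimethylamino on the carbonyl carbon gives no change at the digits printed from compound 2 to compound 3 (within the scatter); this is the first step that changes the amide nitrogen substituents, and the entering ring and hydrogen-bond donor leave the number within the scatter. Set against the pyrazin-2-yl group on the aromatic carbon, cyclopentylcarbamoyl gives a 1.1-fold lower number from compound 1 to compound 3 (0.02 log units; within the scatter), so it stands level with that group, as dimethylcarbamoyl does. Nothing available explains why the number holds across these changes.

From the compounds shown here alone, whether a carboxylic acid on the aromatic carbon, or an amine or a longer chain on the amide nitrogen, would stay level remains open. All three compounds stand level with one another, so they mark no limit to what this position accepts.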